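This account rests on a few compounds, and the source may have more. Where it says the series, first, only, none or still open, it means among the compounds named here.

Measured compounds:
Compound 1 `COc1nc2ccccc2nc1C(=O)Nc1ccc(O)c(CN2CCCCC2)c1` gives 316000 nM in a functional assay on ileum for antagonist activity at 5-hydroxytryptamine receptor 3A (Cavia porcellus); on this read-out lower numbers stand for tighter binding and higher numbers for weaker binding.
Compound 2 `COc1nc2ccccc2nc1C(=O)Nc1cc(CN2CCN(C)CC2)c(O)c(N2CCN(C)CC2)c1` gives 15800 nM in this assay.

Compound 1 carries the higher of these two numbers, and compound 2 lies far lower, a gap beyond the usual scatter. Compound 3 `CCOc1nc2ccccc2nc1C(=O)Nc1ccc(O)c(CN2CCCCC2)c1` differs from compound 1 by methyl in place of hydrogen on a saturated chain carbon bound to an oxygen on an aromatic ring. Among the measured compounds shown here, no measured pair shows this change, so the expectation is modest: the step from compound 1 to compound 3 is estimated at a 1.3-fold lower number from compound 1 to compound 3 (0.10 log units; within the scatter), not beyond the scatter in either direction. Compound 3 is therefore expected to come in near 250000 nM, with a range from 80000 nM to 800000 nM.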

Compound 3, dissociation constant: 794000 nM
Beside the measured number, compound 3's estimate is 3.2-fold (0.50 log units) below it; low and high end bracket the measured number.
By their numbers in this assay, from the lowest: compound 2; then compound 1; then compound 3.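

The change from methoxy to ethoxy registers in this assay as a 2.5-fold higher number from compound 1 to compound 3 (0.40 log units; beyond the scatter). Among the compounds shown here, this is the first sign that this position responds to a single added methyl on a saturated chain carbon bound to an oxygen on an aromatic ring, and the number moves towards weaker binding. Nothing shown gives a reason for this shift.

For the compounds shown here, with only one step at this position, the compounds leave open whether a longer chain such as propoxy, or an amine there, would raise the number further. Going by these compounds, whether ethoxy acts the same way on the core of compound 2 also remains open.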